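Cytotoxicity limits and a trifluoroacetyl swap

The compounds below may be only part of what the source reports. "The series", "measured", "known", "first", "only" and "open" are said of these compounds alone.

Compound 1 `COc1cc2ncnc(-n3nc(-c4ccccc4)nc3N)c2cc1OC`: > 50000 nM (a limit)
Compound 2 `COc1cc2ncnc(-n3nc(-c4ccccn4)nc3N)c2cc1OCCCNC(=O)CN1C[C@@H](C)O[C@@H](C)C1`: > 25000 nM (a limit)
Compound 3 `COc1cc2ncnc(-n3nc(-c4ccccn4)nc3N)c2cc1OCCCCNC(=O)OC(C)(C)C`: > 7000 nM (a limit)

In an ADME assay on BJ cells (Homo sapiens) for cytotoxicity, with a stated time of 72 h (on this read-out higher numbers stand for an effect only at larger amounts of compound and lower numbers for an effect already at smaller amounts), compound 3 gives > 7000 nM as a limit, not a number, and the other two values are limits as well. Compound 4 `COc1cc2ncnc(-n3nc(-c4ccccn4)nc3N)c2cc1OCCCNC(=O)C(F)(F)F` brings this change: ((trifluoromethyl)carbonyl)amino in place of ((tert-butoxycarbonyl)amino)methyl on a saturated chain carbon, three bonds along the chain from an oxygen on an aromatic ring with ((trifluoromethyl)carbonyl)amino in place of ((tert-butoxycarbonyl)amino)methyl on a saturated chain carbon. Going by the values given here, the one measured step at this place, a step that the two limits leave unreadable from compound 2 to compound 3, has limits at both ends, so it offers no size to carry over. The expected step is small and upward, a step that the limit leaves unreadable from compound 3 to compound 4, a weak estimate with no measured number behind it. Compound 4 is estimated at 15000 nM, with an expected range from 6000 nM to 50000 nM in this assay, and the assay may again report only a limit.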

Compound 4, half-maximal effective concentration: > 7000 nM
Compound 4: no number, only a limit; the forecaster's own chance of this, stated with the estimate: 65%; the middle value does not contradict the limit.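

Going by these compounds alone, the values of compound 2, compound 3 and compound 4 are all limits, and no step between them can be read in this assay. The compounds shown leave open the concentration at which any of them would reach a half-maximal effect on these cells.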